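The source may report more compounds than this note shows. Statements on the series, on what has been measured and on what is new or still open speak of the compounds shown alone.

The core of compound 1 `O=C1O[C@@H](CO)CN1c1ccc(-n2cc(-c3ccccn3)cn2)c(F)c1` bears a hydroxy group on a saturated chain carbon, and in an ADME assay on L02 cells (Homo sapiens) for cytotoxicity, read by MTT assay, with a stated time of 48 h (a lower number here means a stronger inhibitor, a higher number a weaker inhibitor), compound 1 gives 59 ug/mL. Compound 2 `O=C1O[C@@H](CN2CCCCC2)CN1c1ccc(-n2cc(-c3ccccn3)cn2)c(F)c1` bears piperidin-1-yl there, and its result is a limit: compound 2 gives > 400 ug/mL. Compound 3 `O=C1O[C@@H](CN2CCC(c3ccc(F)cc3)CC2)CN1c1ccc(-n2cc(-c3ccccn3)cn2)c(F)c1` also reaches only a limit: compound 3 gives > 400 ug/mL. Compound 2 therefore stands at the limit of > 400 ug/mL in this assay, at which 2 of the 3 values shown sit.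

Compound 4 `CC(=O)OC[C@H]1CN(c2ccc(-n3cc(-c4ccccn4)cn3)c(F)c2)C(=O)O1` has not yet been measured. Its difference from compound 2 is acetoxy in place of piperidin-1-yl on a saturated chain carbon bound to a saturated ring carbon, which is acetoxy in place of piperidin-1-yl. The closest guide is an at least 6.7-fold higher number from compound 1 to compound 2 (0.83 log units; beyond the scatter), where piperidin-1-yl replaced hydroxy at the same carbon. The other measured change, a step that the two limits leave unreadable from compound 2 to compound 3, adds 4-fluorophenyl in place of hydrogen on a saturated ring carbon and offers no guide here. Since acetoxy, like hydroxy, replaces piperidin-1-yl at that carbon, part of the first step is expected to reverse, moving toward a lower number in this assay. The expected change is an at least 3.3-fold lower number from compound 2 to compound 4 (0.52 log units; beyond the scatter). For compound 4 the estimate is 120 ug/mL, with an expected range from 40 ug/mL to 400 ug/mL.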

Compound 4, half-maximal inhibitory concentration: > 400 ug/mL
Compound 4 gave a limit, no number; the forecaster's own chance of this, stated with the estimate: 30%; middle value at least 3.3-fold (0.52 log units) from the limit.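

Acetyl in place of hydrogen on the oxygen gives an at least 6.7-fold higher number from compound 1 to compound 4 (0.83 log units; beyond the scatter), so in this assay the lower number of the free hydroxy compound is not kept once that oxygen is capped. The higher reading therefore does not require piperidin-1-yl or any other amine at this carbon, since acetoxy, which has no ring, also gives a limit. The step from compound 2 to compound 4 cannot be read, as both results are limits, and compound 1 remains the only one of these compounds with a real number: the limit of > 400 ug/mL in this assay, at which 3 of the 4 values shown sit.

Going by these compounds, the true values of compound 2, compound 3 and compound 4 remain open. On these data alone, whether a free hydroxy alone goes with the lower number also remains open, and a methoxy group, a primary amine or a carboxylic acid on this carbon would test that.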